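The source may report more compounds than this note shows. Statements on the series, on what has been measured and on what is new or still open speak of the compounds shown alone.

In a functional assay (Homo sapiens) for antiproliferative activity (a lower number here means a stronger inhibitor of growth, a higher number a weaker inhibitor of growth), three compounds built on related cores have been measured. Compound 1 `Cc1sc2nc(-c3ccncc3)c(/C=N/NC(=N)N)n2c1C` gives 91200 nM, compound 2 `Cc1cn2c(/C=N/NC(=N)N)c(-c3cccnc3)nc2s1` gives 22400 nM, and compound 3 `N=C(N)N/N=C/c1c(-c2ccccn2)nc2sc(Cl)cn12` gives 20900 nM. Compound 3 thus stands within the scatter of compound 2, while compound 1 carries the higher number, beyond the scatter. Compound 4 `N=C(N)N/N=C/c1c(-c2cccnc2)nc2sc(Cl)cn12` has pyridin-3-yl in place of pyridin-2-yl on an aromatic carbon of compound 3 (pyridin-3-yl in place of pyridin-2-yl on an aromatic carbon). Going by the values given here, no measured pair isolates this change. Compound 2 also bears pyridin-3-yl and gives 22400 nM, although it differs from compound 4 elsewhere. The expected 1.0-fold higher number from compound 3 to compound 4 (0.00 log units; within the scatter) is therefore small, with no shift beyond the scatter anticipated in this assay. For compound 4 the estimate is 21000 nM, with an expected range of 10000 nM to 45000 nM.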

Compound 4, concentration for total growth inhibition: 46800 nM
Beside the measured number, compound 4's estimate is 2.2-fold (0.35 log units) below it; the measured number lies above the stated range.
By their numbers in this assay, from the lowest: compounds 3 and 2 (each within the scatter of the next); then compounds 4 and 1 (each within the scatter of the next).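

In this assay, going by these compounds alone, pyridin-3-yl in place of pyridin-2-yl gives a 2.2-fold higher number from compound 3 to compound 4 (0.35 log units; beyond the scatter), so this change on the aromatic carbon has a modest effect beyond the scatter, which no earlier pair could show. With pyridin-3-yl held in place, chloro in place of methyl on an aromatic carbon gives a 2.1-fold higher number from compound 2 to compound 4 (0.32 log units; beyond the scatter), also a modest step. No supporting evidence bears on the origin of either step. The compounds shown leave open how phenyl or an aminomethyl group would read at the pyridine-bearing carbon. They also leave open whether a methoxy group would differ from chloro or methyl on the other aromatic carbon.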